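Furanyl Amide to Propanamide: Expected Tolerance on THP-1 Cells

This account rests on a few compounds, and the source may have more. Where it says the series, first, only, none or still open, it means among the compounds named here.

Measured compounds:
Compound 1 `Cn1c(-c2cccc([N+](=O)[O-])c2)cnc1NC(=O)c1ccc(F)cc1`: in a toxicity assay on THP-1 cells (Homo sapiens) for inhibition (a lower number here means that less compound is tolerated, a higher number that more compound is tolerated), compound 1 gives > 50000 nM, which is a limit of the assay and not a number.
Compound 2 `COc1ccc(-c2cnc(NC(=O)c3ccco3)n2C)cc1`: in this assay compound 2 gives > 100000 nM, again a limit of the assay.
Compound 3 `Cc1ccc(C(=O)Nc2ncc(-c3ccccc3)o2)cc1`: in this assay compound 3 gives 26000 nM.

Compound 2 stands at the upper edge of what the numbers show: its value in this assay is a limit, and among the three measured values a further value is likewise a limit. Only compound 3 is given as a plain number. No pair of these compounds differs in a single place, so no measured step is available, and the evidence consists of the limits themselves: the limit of > 100000 nM in this assay, at which 1 of the 3 values shown sits, and (the limit of > 50000 nM in this assay, at which 1 of the 3 values shown sits).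

Compound 4 `CCC(=O)Nc1ncc(-c2ccc(OC)cc2)n1C` keeps the core of compound 2 and changes one group: ethyl in place of furan-2-yl on a carbonyl carbon. Without a measured step of this kind, the step of a number no higher from compound 2 to compound 4 (the limit leaves the size open) in this assay is expected to stay within the scatter, with no direction beyond it. Compound 4 is therefore estimated at 100000 nM, with a range from 50000 nM to 200000 nM, and the assay is likely to report only a limit again.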

Compound 4, half-maximal cytotoxic concentration: > 100000 nM
Compound 4 gave a limit, no number (the forecaster's own chance of this, stated with the estimate: 70%); the middle value lies on the limit itself.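

In this assay compound 2 gives > 100000 nM, a limit of the assay and not a number. Going by these compounds alone, compound 4 gives > 100000 nM, again a limit, and no step between compound 2 and compound 4 can be read. The compounds shown leave open whether ethyl in place of furan-2-yl on a carbonyl carbon changes tolerance at all.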